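Aldehyde to carboxylic acid on two related cores

The source may hold more compounds than are shown below. What is called first, only, known or untested is meant among the compounds shown, and "the series" means these compounds.

Measured compounds:
compound 1 `Cn1nc(Cc2nnc(SCC(=O)Nc3ccc(Cl)cc3Cl)n2CCC=O)c2ccccc2c1=O` — 6000 nM
compound 2 `Cn1nc(Cc2nnc(SCC(=O)Nc3ccc(Cl)cc3Cl)n2CCC(=O)O)c2ccccc2c1=O` — > 30000 nM
compound 3 `Cn1c(Cc2nn(CCC=O)c(=O)c3ccccc23)nnc1SCCCCCCCC(=O)Nc1ccc(Cl)cc1Cl` — 8900 nM

In an assay on 32D cells for inhibition of interleukin-15 (Mus musculus), read by resazurin assay, with stated times of 30 min and 2.5 days, in the presence of a further agent that is not named here (on this read-out higher numbers stand for weaker inhibition and lower numbers for stronger inhibition), compound 1 gives 6000 nM. Compound 2 reaches only a limit of this assay, > 30000 nM. The change hydroxy in place of hydrogen on a carbonyl carbon thus gives an at least 5.0-fold higher number from compound 1 to compound 2 (0.69 log units; beyond the scatter), a step bounded by the limit of > 30000 nM in this assay, at which 1 of the 3 values shown sits. Compound 3 gives 8900 nM, within the scatter of compound 1; the difference between the cores of compound 1 and compound 3 is not broken down here.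

Compound 4 `Cn1c(Cc2nn(CCC(=O)O)c(=O)c3ccccc23)nnc1SCCCCCCCC(=O)Nc1ccc(Cl)cc1Cl` is not yet measured. The change hydroxy in place of hydrogen on a carbonyl carbon is the same change as that from compound 1 to compound 2, the place being identical in both. The step expected from compound 3 is a 5.1-fold higher number from compound 3 to compound 4 (0.70 log units; beyond the scatter), resting on the weakening seen in an at least 5.0-fold higher number from compound 1 to compound 2 (0.69 log units; beyond the scatter). For compound 4 the estimate in this assay is 45000 nM, between 15000 nM and 150000 nM, most likely reported only as a limit.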

Compound 4, half-maximal inhibitory concentration: > 30000 nM
Compound 4: no number, only a limit; the forecaster's own chance of this, stated with the estimate: 70%; the middle value does not contradict the limit.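

In this assay the change from 2-formylethyl to 2-carboxyethyl gives an at least 3.3-fold higher number from compound 3 to compound 4 (0.52 log units; beyond the scatter), so on the core of compound 3 the change again goes in the direction seen on the core of compound 1. Set side by side, the two steps read: the same change on two cores in this assay, an at least 5.0-fold higher number (0.69 log units; beyond the scatter) from compound 1 to compound 2 and an at least 3.3-fold higher number (0.52 log units; beyond the scatter) from compound 3 to compound 4; the limit leaves it open whether they differ. The direction therefore carries from one core to the other in these two pairs, but the size of the step is not established, and compound 2 and compound 4 give limits rather than numbers: the limit of > 30000 nM in this assay, at which 2 of the 4 values shown sit.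

On these data alone, the true size of each step remains open. Also open, as far as these compounds go, is how an alcohol or an amine in place of the carboxy group, or a longer chain carrying it, would read on either core.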